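A few compounds are considered here, and "the series" means these few. Any claim that something is new, unique, unknown or untested is made for them only; others in the source may bear on it.

The series shares the core of compound 1, `CCS(=O)(=O)N1CCC(CN(C2Cc3cc(C#N)ccc3N(Cc3cncn3C)C2)S(=O)(=O)c2ccccn2)CC1`, and varies the substituent on the sulfonamide nitrogen in a ring. Among the measured compounds shown here, in an ADME assay on Caco-2 cells (Homo sapiens) for permeability, in the apical to basolateral direction (on this read-out lower numbers stand for lower permeability and higher numbers for higher permeability), compound 1 gives 0.1 10^-6 cm/s, the lowest of the three numbers measured so far. Compound 2, `Cn1cnc(S(=O)(=O)N(Cc2cccc(-n3cccc3)c2)C2Cc3cc(C#N)ccc3N(Cc3cncn3C)C2)c1`, gives 0.2 10^-6 cm/s in this assay; its value and that of compound 1 lie within the scatter, so no order between them is claimed. For the measured compounds named here, compound 3, `Cn1cncc1CN1CC(N(CC2CCN(C(=O)c3ccco3)CC2)S(=O)(=O)c2ccccn2)Cc2cc(C#N)ccc21`, gives 0.5 10^-6 cm/s in this assay, and the step of a 5.0-fold higher number from compound 1 to compound 3 (0.70 log units; beyond the scatter) is the one measured change that goes beyond the scatter; it exchanges the ethylsulfonyl of compound 1 for a (furan-2-yl)carbonyl on an amine nitrogen in a ring.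

Compound 4, `Cn1cncc1CN1CC(N(CC2CCN(S(=O)(=O)c3ccccc3)CC2)S(=O)(=O)c2ccccn2)Cc2cc(C#N)ccc21`, differs from compound 1 in a single place: phenyl in place of ethyl on a sulfonyl sulfur. Going by the values given here, no phenylsulfonyl has been measured, so the only step bearing on the change is a 5.0-fold higher number from compound 1 to compound 3 (0.70 log units; beyond the scatter), which alters the same ethylsulfonyl and was modest in size. Among the compounds with values here, no measured step has moved the number downward from compound 1. The expected step for compound 4 in this assay is therefore a 2.0-fold higher number from compound 1 to compound 4 (0.30 log units; within the scatter), upward and small, possibly not beyond the scatter. The estimate for compound 4 is 0.2 10^-6 cm/s, with a range from 0.08 10^-6 cm/s to 0.6 10^-6 cm/s.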

Compound 4, apparent permeability: 0.1 10^-6 cm/s
Compound 4: middle estimate off by 2.0-fold (0.30 log units), on the high side; low and high end bracket the measured number.
By their numbers in this assay, from the lowest: compounds 1, 4 and 2 (each within the scatter of the next); then compound 3.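

On the sulfonyl sulfur in this assay, phenyl in place of ethyl gives no change at the digits printed from compound 1 to compound 4 (within the scatter), so this larger group, with its six-membered aromatic ring, leaves no readable difference from the ethyl of the core compound. Set against the phenylsulfonyl, the (furan-2-yl)carbonyl now stands apart from two different sulfonyl groups on the same amine nitrogen in a ring, with a 5.0-fold lower number from compound 3 to compound 4 (0.70 log units; beyond the scatter) alongside the earlier 5.0-fold higher number from compound 1 to compound 3 (0.70 log units; beyond the scatter); among compounds 1, 3 and 4, the two sulfonyl compounds give the lower numbers, and none of these three goes against that, although the carbonyl side rests on compound 3 alone. No measurement is at hand that would explain this difference.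

The compounds shown leave open whether the higher number goes with the carbonyl link or with the furan ring, which an acetyl or a benzoyl group on the same nitrogen would help separate. From the compounds shown here alone, it is also open whether the flat result on the sulfonyl sulfur extends to a longer alkyl chain or to a phenyl ring carrying an amine or a carboxylic acid.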